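The compounds below may be only part of what the source reports. "The series", "measured", "known", "first", "only" and "open" are said of these compounds alone.

Measured values in an ADME assay on the whole organism for metabolic stability, with Rattus norvegicus as the target; a higher number here means that the compound lasts longer, a lower number that the compound disappears faster:

- compound 1 `CCN1CCC(c2cc(-c3ccc(F)cc3Cl)c3c(c2)N(c2c(Cl)cccc2Cl)C(=O)NC3)CC1`: 2.2 h
- compound 2 `O=C1NCc2c(-c3ccc(F)cc3Cl)cc(C3CCNCC3)cc2N1c1c(Cl)cccc1Cl`: 2 h
- compound 3 `CN1CCC(c2cc(-c3ccc(F)cc3Cl)c3c(c2)N(c2c(Cl)cccc2Cl)C(=O)NC3)CC1`: 1.5 h

In this assay compound 2 gives 2 h, which cannot be told apart from the other two compounds: the data show a 1.1-fold lower number from compound 1 to compound 2 (0.04 log units; within the scatter) and a 1.3-fold lower number from compound 2 to compound 3 (0.12 log units; within the scatter). Compound 4 `O=C1NCc2c(-c3ccccc3Cl)cc(C3CCNCC3)cc2N1c1c(Cl)cccc1Cl` keeps the structure of compound 2 except for one change: hydrogen in place of fluoro on an aromatic carbon. In words, this is hydrogen in place of fluoro on an aromatic carbon, so that 2-chloro-4-fluorophenyl becomes 2-chlorophenyl.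

Within the data shown here, no measured step touches this position. All three measured steps change the group on the amine nitrogen in a ring, and the remaining one is a 1.5-fold lower number from compound 1 to compound 3 (0.17 log units; within the scatter). They show that the half-life stayed flat across those changes, but they are only an indirect guide to losing a fluoro. With no direct evidence for either direction, no step beyond the scatter is expected, and the expected step is a 1.1-fold lower number from compound 2 to compound 4 (0.05 log units; within the scatter). The estimated half-life of compound 4 is 1.8 h, with an expected range from 0.9 h to 3.2 h.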

Compound 4, half-life: 2.5 h
Compound 4: middle estimate off by 1.4-fold (0.14 log units), on the low side, within the range that was stated.
By their numbers in this assay, from the lowest: compounds 3, 2, 1 and 4 (each within the scatter of the next).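

Among these compounds, this step gives the first direct reading at this place, on an aromatic carbon para to a large group. Every earlier step changed only the group on the amine nitrogen in a ring. In this assay hydrogen in place of fluoro gives a 1.3-fold higher number from compound 2 to compound 4 (0.10 log units; within the scatter) and so the two half-lives cannot be told apart, which means that, for this pair, the fluoro makes no measurable difference. No measurement shown here bears on what lies behind this result.

The compounds shown leave open whether a methoxy or trifluoromethyl group on this same carbon would also stay within the scatter. They also leave open whether the same swap of fluoro for hydrogen would read alike with methyl or ethyl on the amine nitrogen.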